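This account rests on a few compounds, and the source may have more. Where it says the series, first, only, none or still open, it means among the compounds named here.

Compound 1 `O=C(CCc1ccc(C(F)(F)F)cc1)Nc1ccc2nc(N3CC4CC3CN4)ccc2c1` belongs to a small set of amides built on a shared core that carries a cyclic amine on one side and an aryl-substituted chain on the other. In a functional assay on HEK293 cells for activation of melanin-concentrating hormone receptor 1 (Rattus norvegicus), read by inositol phosphate accumulation (on this read-out lower numbers stand for an effect already at smaller amounts and higher numbers for an effect only at larger amounts of compound), compound 1 gives 490 nM, the highest of the two single numbers available. Compound 2 `O=C(CCCCCCCCCCCCc1ccc(C(F)(F)F)cc1)Nc1ccc2nc([N+]34CCC(CC3)CC4)ccc2c1`, which carries a different amine and a longer chain, gives 25 nM in this assay, a lower number that lies well beyond the scatter of repeated measurements. Compound 3 `O=C(CCc1ccc(C(F)(F)F)cc1)Nc1ccc2nc(N3CCCC3)ccc2c1`, the third member, has been measured twice in this assay and gives 320 nM; 320 nM (2 entries).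

Compound 4 `O=C(CCc1ccc(C(F)(F)F)cc1)Nc1ccc2nc(N3CCC4(CCNC4)C3)ccc2c1` has not yet been measured. It differs from compound 1 in one place: a group of 9 heavy atoms (7 carbon, 2 nitrogen; 2 five-membered non-aromatic rings with 1 hetero atom each) in place of a group of 7 heavy atoms (5 carbon, 2 nitrogen; 2 five-membered non-aromatic rings with 1 hetero atom each), on an aromatic carbon. Both the group that leaves and the group that enters are paired five-membered rings with one nitrogen each, with one hydrogen-bond donor and two acceptors, so the change is a rearrangement of a similar amine rather than a change of its kind. Going by the values given here, no comparable step between measured compounds is available, and the numbers for compound 1 and compound 3 show that two different amines at this position give values within the scatter of one another. For compound 4 the step of a 1.2-fold lower number from compound 1 to compound 4 (0.09 log units; within the scatter) is therefore expected to stay within the scatter, in either direction. Compound 4 is estimated to give 400 nM in this assay, with a plausible range from 150 nM to 1300 nM.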

Compound 4, half-maximal effective concentration: 140 nM
Beside the measured number, compound 4's estimate is 2.9-fold (0.46 log units) above it, outside the stated range (below it).
By their numbers in this assay, from the lowest: compound 2; then compound 4; then compound 1.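

The change of amine brings a 3.5-fold lower number from compound 1 to compound 4 (0.54 log units; beyond the scatter) in this assay, so the number at this position, on an aromatic carbon next to the ring nitrogen, can shift beyond the usual scatter when one paired-ring amine replaces another. The two groups have the same nitrogen count, the same hydrogen-bond donor and acceptor counts, no net charge, and two five-membered non-aromatic rings each, and the entering group differs in these counts only by having more carbon, so such counts alone do not settle the number here. This is one modest step between a single pair of compounds, so it shows that the position responds to the amine but sets no trend, and no measurement at hand accounts for the shift.

Still open, as far as these compounds go, is how an amine of a different kind would behave at this position, for example piperazine, morpholine or an open-chain dimethylamino group, and whether a still larger paired-ring amine would bring the number further down or back up. Going by these compounds alone, also open is whether the amine of compound 4 would give a similar step on a longer chain, such as the one carried by compound 2.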